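Nitrogen substituent on the shared core: ethyl to cyclohexyl

The source may hold more compounds than are shown below. What is called first, only, known or untested is meant among the compounds shown, and "the series" means these compounds.

Measured so far:
compound 1, `CC(C)c1onc(-c2c(Cl)cccc2Cl)c1COc1ccc(-c2nc3ccc(C(=O)O)cc3n2CC(C)(C)C)cc1`, 24.8 nM
compound 2, `CCCn1c(-c2ccc(OCc3c(-c4c(Cl)cccc4Cl)noc3C(C)C)cc2)nc2ccc(C(=O)O)cc21`, 96.4 nM
compound 3, `CC(C)c1onc(-c2c(Cl)cccc2Cl)c1COc1ccc(-c2nc3ccc(C(=O)O)cc3n2CC2CC2)cc1`, 29.1 nM

In an assay on isolated protein for agonist activity at Bile acid receptor (Homo sapiens), read by TR-FRET (a lower number here means that less compound is needed, a higher number that more compound is needed for the effect), compound 2 stands highest of the three numbers; its nearest neighbour is compound 3, and the step of a 3.3-fold lower number from compound 2 to compound 3 (0.52 log units; beyond the scatter) lies beyond the scatter, as does a 3.9-fold higher number from compound 1 to compound 2 (0.59 log units; beyond the scatter) in the other direction. Compound 1 and compound 3 sit within the scatter of each other, as a 1.2-fold higher number from compound 1 to compound 3 (0.07 log units; within the scatter) shows.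

Compound 4, `CC(C)c1onc(-c2c(Cl)cccc2Cl)c1COc1ccc(-c2nc3ccc(C(=O)O)cc3n2CC2CCCCC2)cc1`, is not yet measured. The change from compound 2 is cyclohexyl in place of ethyl on a saturated chain carbon bound to an aromatic nitrogen. The two measured steps that bear on it both replace a small group at this position with a branched or ring-bearing one, and both gave lower numbers of modest size: a 3.3-fold lower number from compound 2 to compound 3 (0.52 log units; beyond the scatter) and, read from compound 2 back to compound 1, a step of similar size. A cyclohexyl group at the same carbon is therefore expected to give a modestly lower number in this assay than compound 2, with the wider range reflecting that no group of this size has yet been tried there. Compound 4 is estimated at 30 nM (range 12 nM to 90 nM), which means an expected step of a 3.2-fold lower number from compound 2 to compound 4 (0.51 log units; beyond the scatter).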

Compound 4, half-maximal effective concentration: 19.9 nM
Estimate against measurement, compound 4: 1.5-fold (0.18 log units) above; the range from low to high includes it.
By their numbers in this assay, from the lowest: compounds 4, 1 and 3 (each within the scatter of the next); then compound 2.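

Cyclohexyl on a saturated chain carbon bound to an aromatic nitrogen confirms that a ring as large as this one is accepted in this assay, with the number still lower than with ethyl (a 4.8-fold lower number from compound 2 to compound 4 (0.69 log units; beyond the scatter)). Cyclohexyl cannot be told apart from cyclopropyl (a 1.5-fold lower number from compound 3 to compound 4 (0.17 log units; within the scatter)) or from tert-butyl (a 1.2-fold lower number from compound 1 to compound 4 (0.10 log units; within the scatter)), so compounds 1, 3 and 4 form one group, with no order among them, and only compound 2 stands apart. No measurement available gives a reason for the separation of ethyl from the other three groups.

The compounds shown leave open whether a phenyl ring or an amine on this carbon would stand with compounds 1, 3 and 4 or with compound 2. They also leave open whether a ring larger than cyclohexyl would stay level with that group.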